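This account rests on a few compounds, and the source may have more. Where it says the series, first, only, none or still open, it means among the compounds named here.

Compound 1 `O=C(Nc1ccc(Cl)c(-c2nnc3c(Cl)cccn23)c1)c1ccccn1` gives 75500 nM in a functional assay on HeLa cells (Homo sapiens) for antiproliferative activity, read by MTT assay, with a stated time of 72 h; a higher number here means a weaker inhibitor, a lower number a stronger inhibitor.
Compound 2 `O=C(Nc1ccc(Cl)c(-c2nnc3c(Cl)cccn23)c1)c1cccnc1` gives only a limit in this assay, > 100000 nM.

Among the compounds with values here, compound 1 is the only compound of the pair with a numeric result in this assay; the remaining value is a limit of the assay (the limit of > 100000 nM in this assay, at which 1 of the 2 values shown sits). Within the data shown here, the one measured step, pyridin-3-yl in place of pyridin-2-yl on the carbonyl carbon, runs an at least 1.3-fold higher number from compound 1 to compound 2 (0.12 log units; that floor lies within the scatter), a floor that itself lies within the scatter, so no direction is firmly established by it.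

Compound 3 `CS(=O)(=O)c1cccc(C(=O)Nc2ccc(Cl)c(-c3nnc4c(Cl)cccn34)c2)c1` is not yet measured. It differs from compound 1 by 3-(methylsulfonyl)phenyl in place of pyridin-2-yl on a carbonyl carbon. The measured step bears on it only loosely: both replace the aryl group on the carbonyl carbon, but that step compares two pyridyl isomers and does not reach a sulfonyl-bearing phenyl. With compound 1 already weak and compound 2 at the limit, a step in this assay beyond the scatter in either direction is not indicated by the data. Compound 3 is therefore expected at roughly the level of compound 1, an estimated 1.1-fold higher number from compound 1 to compound 3 (0.03 log units; within the scatter), giving an estimate of 80000 nM with a range from 30000 nM to 200000 nM.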

Compound 3, half-maximal inhibitory concentration: 86400 nM
Compound 3: middle estimate off by 1.1-fold (0.03 log units), on the low side, and the stated range covers the measured number.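

Replacing pyridin-2-yl with 3-(methylsulfonyl)phenyl on the carbonyl carbon gives a 1.1-fold higher number from compound 1 to compound 3 (0.06 log units; within the scatter). Within the data shown here, this is the first comparison at this position in this assay in which both compounds have numeric results, and it shows no separation between them, even though the entering group has a six-membered aromatic ring of carbon only and carries a methylsulfonyl group that the leaving pyridin-2-yl lacks. Against pyridin-3-yl, the same replacement gives an at least 1.1-fold lower number from compound 2 to compound 3 (0.06 log units; that floor lies within the scatter), but this is only a floor, as the result for compound 2 is a limit of the assay: the limit of > 100000 nM in this assay, at which 1 of the 3 values shown sits.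

The compounds shown leave open whether any group on this carbonyl carbon can move the number in this assay beyond the scatter, for instance an aliphatic amine such as piperidine, a carboxylic acid or a longer alkyl chain in place of the aromatic ring. They also leave open how the result would respond to a change anywhere else on the shared core, as all three compounds differ only on the carbonyl carbon.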